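Amide side-chain swap in a trifluoromethyl benzimidazole series

A few compounds are considered here, and "the series" means these few. Any claim that something is new, unique, unknown or untested is made for them only; others in the source may bear on it.

Compound 1 `Oc1ccc(-c2nc3cc(C(F)(F)F)ccc3[nH]2)cc1` gives 17000 nM in an ADME assay on MT4 cells (Homo sapiens) for cytotoxicity, read by MTT assay, with a stated time of 96 h; a higher number here means that more compound is tolerated, a lower number that less compound is tolerated. Compound 2 `Cn1c(-c2ccc([N+](=O)[O-])cc2)nc2cc(C(F)(F)F)ccc21` reaches only the limit of this assay, >= 100000 nM. Compound 3 `CN1CCN(CC(=O)Nc2ccc(-c3nc4cc(C(F)(F)F)ccc4n3C)cc2)CC1` gives 22000 nM in this assay.

Compound 3 thus sits within the scatter of compound 1, and its value is one of two numbers alongside one limit (the limit of >= 100000 nM in this assay, at which 1 of the 3 values shown sits). Compound 4 `Cn1c(-c2ccc(NC(=O)CN3CCCC3)cc2)nc2cc(C(F)(F)F)ccc21` has not been measured. It differs from compound 3 in the amide side chain only: pyrrolidin-1-yl in place of 4-methylpiperazin-1-yl on a saturated chain carbon bound to a carbonyl carbon. Within the data shown here, no step between measured compounds covers a change of this kind, so the expected step in this assay is taken to be small, with no direction beyond the scatter claimed. Compound 4 is therefore expected to give about 20000 nM, between 7000 nM and 60000 nM, a step of a 1.1-fold lower number from compound 3 to compound 4 (0.04 log units; within the scatter).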

Compound 4, half-maximal cytotoxic concentration: 16000 nM
Estimate against measurement, compound 4: 1.3-fold (0.10 log units) above, within the range that was stated.
By their numbers in this assay, from the lowest: compounds 4, 1 and 3 (each within the scatter of the next). At a limit, above all of these: compound 2.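

In this assay, the swap of rings on the amide side chain shows a 1.4-fold lower number from compound 3 to compound 4 (0.14 log units; within the scatter), so the two rings are not told apart at this place. Among these compounds, on the aromatic carbon, the full side chain in place of nitro shows an at least 6.2-fold lower number from compound 2 to compound 4 (0.79 log units; beyond the scatter), the only step here beyond the scatter. Compound 2 stands at a limit, not a number: the limit of >= 100000 nM in this assay, at which 1 of the 4 values shown sits.

Going by these compounds, it remains open how an open-chain amine such as diethylamino or a carboxylic acid would read on this saturated chain carbon. Which part of the side chain carries the larger step also remains open.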